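Swapping a dimethylamino for a methylpyrrolidine on a kinase core

The source may hold more compounds than are shown below. What is called first, only, known or untested is meant among the compounds shown, and "the series" means these compounds.

This account follows one change on the core of compound 1 `CN(C)c1c(C#N)c2c(N)ncnc2n1C` and what it might do in an assay on isolated protein for inhibition of Leucine-rich repeat serine/threonine-protein kinase 2 variant G2019S (Homo sapiens), read by TR-FRET and LanthaScreen, with stated times of 50 min and 30 min, in the presence of a further agent that is not named here; a higher number here means a weaker inhibitor, a lower number a stronger inhibitor. Among the compounds with values here, compound 1 gives 3760 nM, the highest of the two numbers known here. Within the data shown here, the only other measured compound, compound 2 `Cc1nn(CC(C)(C)O)cc1Nc1nc(N)c2c(C#N)c(N3CCC[C@H]3C)n(C)c2n1`, gives 42 nM, a number far lower and well beyond the scatter; compound 2 differs from compound 1 in more than one place, so no single step can be read from that pair. Compound 3 `C[C@H]1CCCN1c1c(C#N)c2c(N)ncnc2n1C` is the untested compound: 2-methylpyrrolidin-1-yl in place of dimethylamino on an aromatic carbon. Compound 2 carries the same 2-methylpyrrolidin-1-yl group, but nothing isolates its share of the gap. The step from compound 1 to compound 3 is therefore expected to be modest, most likely toward a lower number, a 2.5-fold lower number from compound 1 to compound 3 (0.40 log units; beyond the scatter). Compound 3 is estimated at 1500 nM, with a plausible range from 400 nM to 6000 nM.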

Compound 3, half-maximal inhibitory concentration: 3080 nM
Compound 3: the middle estimate sits 2.1-fold (0.31 log units) below what was measured; measured number inside the range.
By their numbers in this assay, from the lowest: compound 2; then compounds 3 and 1 (each within the scatter of the next).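

In this assay the swap reads as a 1.2-fold lower number from compound 1 to compound 3 (0.09 log units; within the scatter), so on this aromatic carbon, next to the ring nitrogen, 2-methylpyrrolidin-1-yl and dimethylamino cannot be told apart on the core of compound 1. The added ring and the defined stereocentre thus leave the number unmoved beyond the scatter, and whatever sets compound 2 apart does not appear in this step. Nothing available here bears on why the two groups give such close numbers.

From the compounds shown here alone, whether a plain pyrrolidine without the methyl, the opposite stereocentre of the 2-methylpyrrolidin-1-yl group, or a morpholine on this carbon would read the same remains open. Also open, going by these compounds, is whether this swap would read alike on a core that carries the further substituent seen in compound 2.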